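The compounds below may be only part of what the source reports. "The series", "measured", "known", "first", "only" and "open" are said of these compounds alone.

Working notes on the series.

Three analogues of the shared core have been measured in an assay on isolated protein for inhibition of Dihydrofolate reductase (Mus musculus); a lower number here means a less potent compound, a higher number a more potent compound, by a factor of ten per unit of this negative logarithm. Compound 1 `CC1(C)N=C(N)N=C(N)N1c1ccc(OCc2cccc(S(=O)(=O)F)c2)c(Cl)c1` gives 7.72; compound 2 `CC1(C)N=C(N)N=C(N)N1c1ccc(OCc2ccc(Cl)c(S(=O)(=O)F)c2)c(Cl)c1` gives 8; compound 3 `CC1(C)N=C(N)N=C(N)N1c1ccc(OCc2cccc(Cl)c2S(=O)(=O)F)c(Cl)c1` gives 7.42. Compound 3 and compound 2 have the same atoms joined differently, and the difference between the two cores is not broken down here.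

The change from compound 2 to compound 1, (hydrogen in place of chloro on an aromatic carbon), gave a number 0.28 log units lower from compound 2 to compound 1 (within the scatter).

Compound 4 `CC1(C)N=C(N)N=C(N)N1c1ccc(OCc2ccccc2S(=O)(=O)F)c(Cl)c1` is not yet measured. It differs from compound 3 by hydrogen in place of chloro on an aromatic carbon. Among the measured compounds shown here, this is the same kind of change as the one from compound 2 to compound 1, but not the same: in compound 1 the entering hydrogen sits para to a large group, in compound 4 it sits meta to a large group. For the measured compounds named here, with only one earlier example, the step from compound 3 to compound 4 in this assay is expected to be small, a number 0.17 log units lower from compound 3 to compound 4 (within the scatter), resting on compound 2 to compound 1 having given a number 0.28 log units lower from compound 2 to compound 1 (within the scatter). Compound 4 is therefore estimated at 7.25, with a range from 6.75 to 7.75.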

Compound 4, logarithm of the reciprocal of the active concentration, log(1/C): 7.43
Compound 4: middle estimate off by 0.18 log units, on the low side, within the range that was stated.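

In this assay, hydrogen in place of chloro on an aromatic carbon ortho to a fluorosulfonyl group gave a number 0.01 log units higher from compound 3 to compound 4 (within the scatter). Set beside the earlier example, the two results cannot be told apart, so the change carries across these two cores without a measurable difference between them: the same change on two cores in this assay, a number 0.28 log units lower (within the scatter) from compound 2 to compound 1 and a number 0.01 log units higher (within the scatter) from compound 3 to compound 4, 0.29 log units apart, within the scatter of two such steps This shows only that both steps are small in this assay on these two cores; it does not show that removing chloro is without effect on other cores, at other places on the ring, or in any other assay.

The compounds shown leave open whether a different substituent on that aromatic carbon, such as methyl, methoxy or a nitrile, would behave as chloro and hydrogen do here. They also leave open whether the same small steps would hold if a sulfonamide or a carboxylic acid stood where the fluorosulfonyl group stands.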